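Bromo for fluoro on the anilide ring: oral bioavailability

The compounds below may be only part of what the source reports. "The series", "measured", "known", "first", "only" and "open" are said of these compounds alone.

The series is read in an in vivo ADME assay on the whole organism for pharmacokinetics, with Rattus norvegicus as the target; on this read-out lower numbers stand for lower oral bioavailability and higher numbers for higher oral bioavailability. Compound 1 `CNC(=N)c1cccc(/C(C)=C(/F)C(=O)Nc2ccc(-c3ccncc3S(N)(=O)=O)cc2)c1` gives 0.4% in this assay. Going by the values given here, compound 2 `C/C(=C(\F)C(=O)Nc1ccc(-c2ccccc2S(N)(=O)=O)cc1F)c1ccc2ccnc(N)c2c1` gives 13.5% in this assay, the higher of the two numbers measured so far, with compound 1 as its nearest neighbour and the gap between them beyond the usual scatter.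

Compound 3 `C/C(=C(\F)C(=O)Nc1ccc(-c2ccccc2S(N)(=O)=O)cc1Br)c1ccc2ccnc(N)c2c1` carries bromo in place of fluoro on an aromatic carbon. Among the compounds with values here, no measured pair shows this change, so no measured step constrains it. The step is expected to stay within the scatter, with no clear direction, a number 1.5 percentage points lower from compound 2 to compound 3 (within the scatter). Compound 3 is estimated at 12%, in a range from 3% to 28%.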

Compound 3, oral bioavailability: 30.1%
Beside the measured number, compound 3's estimate is 18.1 percentage points below it; measured number outside the range, above it.
By their numbers in this assay, from the lowest: compound 1; then compound 2; then compound 3.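

In this assay, bromo in place of fluoro on the aromatic carbon ortho to a large group and meta to a 2-sulfamoylphenyl group gives a number 16.6 percentage points higher from compound 2 to compound 3 (beyond the scatter), so this position responds to a single-atom swap that leaves the counted donors, acceptors and net charge unchanged. Nothing available bears on the cause of this step. Chloro, methyl or methoxy on this carbon would show whether the step belongs to bromo alone. A single pair also leaves open whether it carries over to the core of compound 1.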